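Purine glycinamide esters: side-chain change on the ester carbon

The compounds below may be only part of what the source reports. "The series", "measured", "known", "first", "only" and "open" are said of these compounds alone.

Measured so far:
- compound 1, `CC(C)[C@H](NC(=O)CN(c1nc(Cl)nc2[nH]cnc12)C1CC1)C(=O)OCc1ccccc1`: 17.9%
- compound 2, `C[C@@H](O)[C@H](NC(=O)CN(c1nc(Cl)nc2[nH]cnc12)C1CC1)C(=O)OCc1ccccc1`: 12.8%

In a functional assay on the whole organism (Tail, strain ICR) with Mus musculus as the target, in the tail flick test, with a stated time of 150 min, at a dose of 25 umol/kg by the oral route (a lower number here means a weaker effect, a higher number a stronger effect of the compound at the dose given), compound 2 holds the lower of the two numbers, the nearest being compound 1, though the step of a number 5.1 percentage points lower from compound 1 to compound 2 (within the scatter) stays within the scatter. Compound 3, `N=C(N)NCCC[C@H](NC(=O)CN(c1nc(Cl)nc2[nH]cnc12)C1CC1)C(=O)OCc1ccccc1`, differs from compound 2 by a group of 7 heavy atoms (4 carbon, 3 nitrogen; no ring) in place of a group of 3 heavy atoms (2 carbon, 1 oxygen; no ring), on a saturated chain carbon bound to an amide-type nitrogen and a carbonyl carbon. Within the data shown here, no measured step exchanges a group of this kind, so only the size of the one known step, a number 5.1 percentage points lower from compound 1 to compound 2 (within the scatter), gives a scale, and no move beyond the scatter is expected in this assay. For compound 3 the value expected in this assay is 15%, in the range 4% to 30%. The expected step is a number 2.2 percentage points higher from compound 2 to compound 3 (within the scatter).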

Compound 3, a percentage reported as activity, at one dose (the size of the read-out at that dose, not a potency): 6.12%
Estimate against measurement, compound 3: 8.9 percentage points above; the range from low to high includes it.
By their numbers in this assay, from the lowest: compounds 3, 2 and 1 (each within the scatter of the next, the first and the last beyond it).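

Among these compounds, at this position, a number 11.8 percentage points lower from compound 1 to compound 3 (beyond the scatter) is the first step in this assay to pass the scatter, so the group on the saturated chain carbon can shift this read-out, though only modestly. With a number 6.7 percentage points lower from compound 2 to compound 3 (within the scatter), the same group of 7 heavy atoms stays unresolved from 1-hydroxyethyl, so it separates only from isopropyl. No data at hand bear on the reason for this step. On these data alone, whether an amine or a carboxylic acid at this place would sit with the group of 7 heavy atoms or with isopropyl remains open.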